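The compounds below may be only part of what the source reports. "The series", "measured", "known", "first", "only" and "open" are said of these compounds alone.

Measured in a functional assay on HeLa cells (Homo sapiens) for antiproliferative activity, read by CCK-8 assay, with a stated time of 48 h; on this read-out higher numbers stand for weaker inhibition and lower numbers for stronger inhibition:
Compound 1 `COc1ccc(/C=C\c2cc(OC)c(OC)c(OC)c2)cc1OCc1ccc(CN2CCCC[C@@H]2C(=O)O)cc1` gives > 10000 nM as a limit, not a number
Compound 2 `COc1ccc(/C=C\c2cc(OC)c(OC)c(OC)c2)cc1OCc1ccc(CN2CCCCC2C(=O)O)cc1` gives 14200 nM as a number

Within the data shown here, compound 2 thus holds the only true number here, and the one value beside it is a limit. Compound 3 `COc1ccc(/C=C\c2cc(OC)c(OC)c(OC)c2)cc1OCc1ccc(CNCCO)cc1` carries (2-hydroxyethyl)amino in place of 2-carboxypiperidin-1-yl on a saturated chain carbon bound to an aromatic carbon. Among the measured compounds shown here, the one measured step (a step that the limit leaves unreadable from compound 1 to compound 2) has no readable size given the limit of > 10000 nM in this assay, at which 1 of the 2 values shown sits, and concerns only the fact that one of compounds 1 and 2 is drawn with a defined configuration and the other without, at the place where they differ so it does not bear on this exchange. The expectation therefore rests on the high number of compound 2 (14200 nM) and on the structural change alone. A step toward stronger inhibition in this assay is expected, of uncertain size. Estimated, this is a 3.6-fold lower number from compound 2 to compound 3 (0.55 log units; beyond the scatter) on that scale. For compound 3 the estimate is 4000 nM with an expected range from 500 nM to 20000 nM for the measurement.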

Compound 3, half-maximal inhibitory concentration: 4400 nM
Beside the measured number, compound 3's estimate is 1.1-fold (0.04 log units) below it; measured number inside the range.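

In this assay, among these compounds, the exchange of 2-carboxypiperidin-1-yl for (2-hydroxyethyl)amino gives the first readable step at this position, a 3.2-fold lower number from compound 2 to compound 3 (0.51 log units; beyond the scatter), a modest gain showing that the ring-bearing group can be replaced by a smaller open chain without loss of inhibition. Compound 1 gives > 10000 nM, which is a limit and not a number. Its comparison, an at least 2.2-fold lower number from compound 1 to compound 3 (0.35 log units; beyond the scatter), points the same way but is only a bound, for this reason: the limit of > 10000 nM in this assay, at which 1 of the 3 values shown sits.

The exchange removes the ring and the carboxylic acid together and brings in the hydroxyl, so the compounds shown cannot say which of these changes matters. Going by these compounds, whether a longer chain such as (3-hydroxypropyl)amino, or a simple amine such as dimethylamino, would do better at this place remains open.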